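Replacing a Fluoro with Phenyl on a Bridged Core

The source may report more compounds than this note shows. Statements on the series, on what has been measured and on what is new or still open speak of the compounds shown alone.

Of the compounds shown here, two have been tested in an assay on HEK293 cells for binding affinity to Neuronal acetylcholine receptor; alpha4/beta2 (Homo sapiens); on this read-out lower numbers stand for stronger inhibition and higher numbers for weaker inhibition. Compound 1, with structure `Cc1nc2cc3c(cc2n1-c1ccccc1)C1CNCC3C1`, reaches the limit of the assay at < 5 nM, so for compound 1 only a limit and no number is known. Compound 2, with structure `Fc1cccc2c1C1CNCC2C1`, gives 200 nM in this assay. Going by the values given here, of the two values, only one is a number; the other, that of compound 1, is a limit, as the limit of < 5 nM in this assay, at which 1 of the 2 values shown sits, shows. Among the compounds with values here, no step between two measured compounds that differ in one place is available, so the two values can only be set side by side.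

Compound 3, with structure `c1ccc(-c2cccc3c2C2CNCC3C2)cc1`, is not yet measured. It differs from compound 2 by phenyl in place of fluoro on an aromatic carbon. Within the data shown here, with no measured step on this core to lean on, the expectation is a modest gain beyond the scatter in this assay, estimated as a 2.0-fold lower number from compound 2 to compound 3 (0.30 log units; within the scatter). Compound 3 is therefore expected to give about 100 nM, with a plausible range from 20 nM to 500 nM.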

Compound 3, inhibition constant: 1600 nM
The estimate for compound 3 lay 16-fold (1.20 log units) below the measured number; measured number outside the range, above it.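

In this assay, the aromatic carbon carrying the group does not treat all groups alike: phenyl in place of fluoro gives an 8.0-fold higher number from compound 2 to compound 3 (0.90 log units; beyond the scatter), so this change weakens binding rather than strengthening it. Going by these compounds alone, this is the first step between two compounds that differ in one place, and it shows that going from one heavy atom to six, with one six-membered aromatic ring added, does not help at this position, even though neither group has a hydrogen-bond donor, a hydrogen-bond acceptor or a net charge. The values shown do not explain why the number rises, so the step stands as an observation only.

On these data alone, with only fluoro and phenyl at this position, it remains open whether plain hydrogen, a small methyl group, an amine or a carboxylic acid would give a lower or a higher number than fluoro does. As far as these compounds go, it also remains open whether a phenyl ring carrying a methoxy group would behave like the plain phenyl here, and whether the loss seen with phenyl would appear at another place on the shared core.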